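The compounds below may be only part of what the source reports. "The series", "measured", "known", "first", "only" and "open" are said of these compounds alone.

Compound 1 `Cc1ccc(C(=O)Nc2cccc(C(F)(F)F)c2)cc1-c1ccc2c(-c3cn[nH]c3)n[nH]c2c1` was tested in a functional assay on KG-1 cells (Homo sapiens) for antiproliferative activity, read by CCK-8 assay, with a stated time of 72 h; on this read-out lower numbers stand for stronger inhibition and higher numbers for weaker inhibition. In this assay compound 1 gives only a limit, > 1000 nM, rather than a number. Compound 3 `Cc1ccc(C(=O)Nc2cccc(C(F)(F)F)c2)cc1-c1ccc2c(-c3cnn(C4CCOC4)c3)n[nH]c2c1` differs from compound 1 in one place: oxolan-3-yl in place of hydrogen on an aromatic nitrogen. One related change is already measured: compound 2 `CCn1cc(-c2n[nH]c3cc(-c4cc(C(=O)Nc5cccc(C(F)(F)F)c5)ccc4C)ccc23)cn1` carries an ethyl on the same aromatic nitrogen, and in this assay compound 2 gives 257 nM. That step, an at least 3.8-fold lower number from compound 1 to compound 2 (0.59 log units; beyond the scatter), is known only as a lower bound because the limit of > 1000 nM in this assay, at which 1 of the 2 values shown sits, caps what compound 1 can show. Compound 3 is expected to follow the direction of an at least 3.8-fold lower number from compound 1 to compound 2 (0.59 log units; beyond the scatter), giving an at least 2.8-fold lower number from compound 1 to compound 3 (0.45 log units; beyond the scatter). Compound 3 is therefore estimated at 350 nM, between 100 nM and 1500 nM.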

Compound 3, half-maximal inhibitory concentration: 304 nM
The estimate for compound 3 lay 1.2-fold (0.06 log units) above the measured number; the measured number falls inside the stated range.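

With a second group on this aromatic nitrogen, this assay gives an at least 3.2-fold lower number from compound 1 to compound 3 (0.51 log units; beyond the scatter), so the step seen with ethyl is not confined to ethyl. That step is read against a limit rather than a number: the limit of > 1000 nM in this assay, at which 1 of the 3 values shown sits. Exchanging ethyl for oxolan-3-yl gives a 1.2-fold higher number from compound 2 to compound 3 (0.07 log units; within the scatter), so the ring and the ethyl chain cannot be told apart here. Going by these compounds, whether a longer chain, an amine or a carboxylic acid on this nitrogen would give a similar number stays open. On these data alone, the true size of the step from compound 1 also stays open.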